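Cytotoxicity notes: amino for hydroxy at the thioaryl tail

The source may report more compounds than this note shows. Statements on the series, on what has been measured and on what is new or still open speak of the compounds shown alone.

Compound 1 `Cc1cc(-c2ccoc2)cn2c(CSCCc3ccccc3)cnc12` carries a furan-3-yl group on the shared core. In an ADME assay on HEL cells (Homo sapiens) for cytotoxicity, with a stated time of 3 days (on this read-out lower numbers stand for higher toxicity in this test and higher numbers for lower toxicity in this test), compound 1 gives only a limit, > 4 ug/mL. Among the compounds with values here, compound 2 `Cc1cc(Sc2ccc(O)cc2)cn2c(CSCCc3ccccc3)cnc12` replaces that group with (4-hydroxyphenyl)sulfanyl, and in this assay compound 2 gives 4 ug/mL, the only actual number. Within the data shown here, the single measured step, a number no higher from compound 1 to compound 2 (the limit leaves the size open), has no readable size because of the limit of > 4 ug/mL in this assay, at which 1 of the 2 values shown sits.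

Compound 3 `Cc1cc(Sc2ccc(N)cc2)cn2c(CSCCc3ccccc3)cnc12` differs from compound 2 by amino in place of hydroxy on an aromatic carbon. Among the measured compounds shown here, no measured step touches this kind of change, so nothing from the series argues for a move in either direction. The estimated step is no change at the digits printed from compound 2 to compound 3 (within the scatter), within the usual scatter. Compound 3 is therefore expected to sit at 4 ug/mL, in a range from 2 ug/mL to 8 ug/mL, with a fair chance that only a limit is reported.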

Compound 3, minimum cytotoxic concentration: 20 ug/mL
Estimate against measurement, compound 3: 5.0-fold (0.70 log units) below; the whole stated range lies below it.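

In this assay, exchanging one heavy atom on the thioaryl tail, amino in place of hydroxy on an aromatic carbon para to a large group, is not a neutral swap: a 5.0-fold higher number from compound 2 to compound 3 (0.70 log units; beyond the scatter). Within the data shown here, this is the first step with a readable size, and it runs towards lower toxicity in this test. The two groups match in hydrogen-bond donors, hydrogen-bond acceptors and net charge, so those counts do not separate compound 2 from compound 3.

The step from compound 1 to compound 3 cannot be read because compound 1 gives only a limit: the limit of > 4 ug/mL in this assay, at which 1 of the 3 values shown sits. As far as these compounds go, what lies behind the step stays open, as does whether a methoxy or a dimethylamino group at the same place would give a number nearer compound 2 or compound 3.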